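The source may hold more compounds than are shown below. What is called first, only, known or untested is meant among the compounds shown, and "the series" means these compounds.

Three compounds share one core and are compared in a single cell-growth test. Compound 1 `CC1=C(C(=O)Nc2ccccc2)C(c2cn(-c3ccccc3)nc2-c2ccc(Cl)cc2)NC(=O)N1` is the parent; in a functional assay on MCF7 cells (Homo sapiens) for inhibition, read by sulforhodamine B assay, with a stated time of 24 h (a lower number here means a stronger inhibitor of growth, a higher number a weaker inhibitor of growth), compound 1 gives 65500 nM. Compound 2 `CC1=C(C(=O)Nc2ccccc2)C(c2cn(-c3ccccc3)nc2-c2ccc(Cl)cc2)NC(=S)N1` has a different core, and how the two cores differ is not broken down here; in this assay compound 2 gives 61500 nM. Compound 3 `CC1=C(C(=O)Nc2ccc(C)cc2)C(c2cn(-c3ccccc3)nc2-c2ccc(Cl)cc2)NC(=O)N1` differs from compound 1 only by methyl in place of hydrogen on an aromatic carbon, and in this assay compound 3 gives 69700 nM, which makes the step of a 1.1-fold higher number from compound 1 to compound 3 (0.03 log units; within the scatter). All three numbers lie close together, so none of them can be singled out as stronger or weaker than the others.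

Compound 4 `CC1=C(C(=O)Nc2ccc(C)cc2)C(c2cn(-c3ccccc3)nc2-c2ccc(Cl)cc2)NC(=S)N1` has not yet been measured. It differs from compound 2 by methyl in place of hydrogen on an aromatic carbon, the same change that turns compound 1 into compound 3. The earlier step stayed within the scatter, and on that basis the step of a 1.1-fold higher number from compound 2 to compound 4 (0.03 log units; within the scatter) is expected to be similarly small. For compound 4 the estimated value is 66000 nM, with a likely range from 40000 nM to 110000 nM.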

Compound 4, concentration for 50% growth inhibition: 43500 nM
Estimate against measurement, compound 4: 1.5-fold (0.18 log units) above; the range from low to high includes it.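

On the core of compound 2, the change from phenyl to 4-methylphenyl gives a 1.4-fold lower number from compound 2 to compound 4 (0.15 log units; within the scatter) in this assay, so here too the added methyl leaves the number within normal measurement scatter. Set side by side, the steps on the two cores cannot be told apart: the same change on two cores in this assay, a 1.1-fold higher number (0.03 log units; within the scatter) from compound 1 to compound 3 and a 1.4-fold lower number (0.15 log units; within the scatter) from compound 2 to compound 4, 1.5-fold (0.18 log units) apart, within the scatter of two such steps. This shows that the change is small on both cores, but with steps this small it does not show that a clear effect of a group would carry from one core to the other, and it rests on a single pair of steps in one test.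

The compounds shown leave open whether a group that does shift the number at this position, perhaps a methoxy group, a carboxylic acid or an amine in place of the methyl, would behave alike on both cores. They also leave open whether a longer chain there would do the same.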